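A few compounds are considered here, and "the series" means these few. Any claim that something is new, unique, unknown or untested is made for them only; others in the source may bear on it.

Three compounds of a shared core, differing in the group on a saturated chain carbon bound to a sulfur, have been examined in an assay on CHO cells for displacement of a labelled ligand from adenosine receptor A3 (Homo sapiens), read by scintillation counting, with a stated time of 120 min, tested at 1 uM; on this read-out higher numbers stand for more inhibition at the one concentration tested (going by the name of the read-out) and lower numbers for less inhibition. Compound 1, `CCOc1ccc(-c2c(C#N)c(N)nc(SCc3ccn[nH]3)c2C#N)cc1`, gives 18% in this assay. Compound 3, `CCOc1ccc(-c2c(C#N)c(N)nc(SCC(N)=O)c2C#N)cc1`, gives 20%, and the step of a number 2 percentage points higher from compound 1 to compound 3 (within the scatter) lies within the scatter. Compound 2, `COC(=O)c1cccc(CSc2nc(N)c(C#N)c(-c3ccc(OCC4CC4)cc3)c2C#N)c1`, gives 4% and stands lowest of the three, with both other numbers beyond the scatter above it.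

The next compound, compound 4, `COC(=O)CSc1nc(N)c(C#N)c(-c2ccc(OCC3CC3)cc2)c1C#N`, has not yet been measured. It differs from compound 2 in one place: methoxycarbonyl in place of 3-(methoxycarbonyl)phenyl on a saturated chain carbon bound to a sulfur. Among the compounds with values here, the only measured step at that position, the one from compound 1 to compound 3, was within the scatter, and it exchanged one small group for another; no measured pair tells what removing a 3-(methoxycarbonyl)phenyl from that chain does. The two compounds carrying a small group on that carbon, compound 1 and compound 3, both sit well above compound 2, but they also differ from compound 2 elsewhere, so no single step can be read from them. Compound 4 is therefore expected to move upward by a number 10 percentage points higher from compound 2 to compound 4 (within the scatter), with wide uncertainty. The estimate for compound 4 in this assay is 14%, between 2% and 28%.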

Compound 4, a percentage reported as inhibition, at one concentration (the size of the read-out at that concentration, not a potency): 1%
For compound 4 the middle estimate is 13 percentage points above the measured one; the whole stated range lies above it.
By their numbers in this assay, from the lowest: compounds 4 and 2 (each within the scatter of the next); then compounds 1 and 3 (each within the scatter of the next).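

The step of a number 3 percentage points lower from compound 2 to compound 4 (within the scatter) shows that, on this core in this assay, the six-membered aromatic ring of the 3-(methoxycarbonyl)phenyl group can be removed from the saturated chain carbon bound to a sulfur without a change beyond the scatter. Within the data shown here, this is the first pair read at this position on the core of compound 2, and the exchange keeps the methoxycarbonyl and the counts of hydrogen-bond donors and acceptors, so the ring and the six heavy atoms that go with it account for no measurable difference here. The data offer no explanation for this result.

The compounds shown leave open whether a carboxylic acid, an amine or a longer chain on that carbon would give a number beyond the scatter of compound 2 and compound 4 on this core. They also leave open how carbamoyl or 1H-pyrazol-5-yl would read on this same core, so the higher numbers of compound 1 and compound 3 cannot yet be assigned to the group on that carbon or to the other place where they differ.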